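Two Stereocentres Redrawn in a Cytotoxicity Test

The source may report more compounds than this note shows. Statements on the series, on what has been measured and on what is new or still open speak of the compounds shown alone.

Measured in an ADME assay on Akata cells (Homo sapiens) for cytotoxicity; on this read-out lower numbers stand for higher toxicity in this test and higher numbers for lower toxicity in this test:
- Compound 1 `Nc1nc2c(ncn2/C=C2\C[C@@H]2[C@@H](O)CO)c(=O)[nH]1` gives 61000 nM
- Compound 2 `Nc1ncnc2c1ncn2/C=C1\C[C@H]1[C@H](O)CO` gives 72700 nM
- Compound 3 `Nc1nc2c(ncn2/C=C2/CC2(CO)CO)c(=O)[nH]1` gives 46000 nM

These three numbers differ by no more than the usual scatter of repeated measurements. Compound 2, at 72700 nM, therefore cannot be separated from compound 1 or compound 3. Compound 4 `Nc1ncnc2c1ncn2/C=C1\C[C@@H]1[C@@H](O)CO` keeps the atoms and bonds of compound 2 and differs only in configuration as drawn (the two compounds have the same atoms and bonds and differ only in configuration as drawn: 2 of 3 stereo elements differ; a stereocentre at a saturated ring carbon is drawn R in compound 2 and S in compound 4; a stereocentre at a saturated chain carbon is drawn S in compound 2 and R in compound 4). For the measured compounds named here, a stereocentre at a saturated ring carbon is drawn S instead of R, and a stereocentre at a saturated chain carbon is drawn R instead of S. No measured pair here isolates such a change, so the expectation rests on the close grouping of the three values. In this assay no step beyond the scatter is expected, in either direction. The estimated 1.1-fold lower number from compound 2 to compound 4 (0.05 log units; within the scatter) reflects this. Compound 4 is expected to give 65000 nM (estimated range 30000 nM to 130000 nM).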

Compound 4, half-maximal cytotoxic concentration: 50600 nM
The estimate for compound 4 lay 1.3-fold (0.11 log units) above the measured number, within the range that was stated.
By their numbers in this assay, from the lowest: compounds 3, 4, 1 and 2 (each within the scatter of the next).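

For the compounds shown here, this is the first pair in the set that can be read as a single change, with two stereocentres redrawn together, one at a saturated ring carbon and one at a saturated chain carbon. In this assay, the outcome is a 1.4-fold lower number from compound 2 to compound 4 (0.16 log units; within the scatter), so redrawing these two stereocentres together gives no step beyond the scatter. Nothing else can account for the gap between these two numbers, small as it is, because the comparison rests on a single kind of difference: the fact that compounds 2 and 4 differ only in the configuration as drawn

From the compounds shown here alone, the two stereocentres changed together, so the contribution of each one alone remains open, as does that of the third stereo element, which is the same in both compounds. The compounds shown also leave open how this test responds to a carboxylic acid in place of a hydroxyl, or to a longer chain.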